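The source may report more compounds than this note shows. Statements on the series, on what has been measured and on what is new or still open speak of the compounds shown alone.

Measured so far in a functional assay on MDA-MB-468 cells (Homo sapiens) for cytotoxicity, read by MTT assay, with a stated time of 96 h (a lower number here means a stronger inhibitor, a higher number a weaker inhibitor), are three compounds.
- compound 1 `Cn1c(-c2ccccc2)ccc1-c1ccc(C(=N)N)cc1` gives 3800 nM
- compound 2 `N=C(N)c1ccc(-c2ccc(-c3ccc([N+](=O)[O-])cc3)o2)cc1` gives 3400 nM
- compound 3 `Cc1ccc(-c2ccc(-c3ccc(C(=N)N)cc3)o2)cc1` gives 3700 nM

The values of all three lie within the scatter of one another, so compound 3 cannot be ranked against compound 1 or compound 2. The next compound is compound 4 `N=C(N)c1ccc(-c2ccc(-c3ccc(Br)cc3)o2)cc1`, which has bromo in place of methyl on an aromatic carbon, para to a large group (bromo in place of methyl on an aromatic carbon). The 4-methylphenyl of compound 3 thus becomes 4-bromophenyl. Within the data shown here, one measured step bears on this change, methyl in place of nitro at the same place, and it amounts to a 1.1-fold higher number from compound 2 to compound 3 (0.04 log units; within the scatter) as its whole effect in this assay so far. Among the measured compounds shown here, this is a single step, and no measured step involves bromo. On the strength of that step, the expected change is a 1.1-fold lower number from compound 3 to compound 4 (0.02 log units; within the scatter) with nothing beyond the scatter expected in either direction. Compound 4 is estimated at 3500 nM with an expected range from 1600 nM to 7000 nM in this assay when it is measured.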

Compound 4, half-maximal inhibitory concentration: 2500 nM
Compound 4: the middle estimate sits 1.4-fold (0.15 log units) above what was measured; low and high end bracket the measured number.
By their numbers in this assay, from the lowest: compounds 4, 2, 3 and 1 (each within the scatter of the next).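

In this assay, the aromatic carbon para to a large group now carries bromo as a third group, and the change to it amounts to a 1.5-fold lower number from compound 3 to compound 4 (0.17 log units; within the scatter), while the exchange for nitro amounts to a 1.4-fold lower number from compound 2 to compound 4 (0.13 log units; within the scatter). Among these compounds, each of the steps among methyl, nitro and bromo at this place thus stays within the scatter, so this assay separates none of the three groups; the earlier compounds showed this only for methyl and nitro. No supporting measurement is available to explain this result.

The compounds shown leave open whether an amine, a carboxylic acid or a hydroxyl group at this same place would move the number beyond the scatter. They also leave open whether a methoxy group or a longer alkyl chain there would do so.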